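The source may hold more compounds than are shown below. What is called first, only, known or untested is meant among the compounds shown, and "the series" means these compounds.

Measured compounds:
Compound 1, `C[S+]([O-])/C=C/c1cc(=O)c2cc(Cl)ccc2o1`, gives 1700 nM in a functional assay on A549 cells (Homo sapiens) for cytotoxicity, with a stated time of 48 h; on this read-out higher numbers stand for weaker inhibition and lower numbers for stronger inhibition.
Compound 2, `Cc1cccc2oc(/C=C/[S+](C)[O-])cc(=O)c12`, gives 1300 nM in this assay.

On the numbers available, compound 1 has the higher of the two values, but its gap to compound 2 lies within the scatter, so the two cannot be told apart. Compound 3, `CC(C)CC(=O)Oc1ccc2oc(/C=C/[S+](C)[O-])cc(=O)c2c1`, has not yet been measured in this assay. Its difference from compound 1 is (isobutylcarbonyl)oxy in place of chloro on an aromatic carbon. Among the compounds with values here, only two values are known, and neither shows how a change at this place affects the read-out, so there is no measured step to lean on. The expectation is therefore a step from compound 1 to compound 3 of a 1.1-fold lower number from compound 1 to compound 3 (0.05 log units; within the scatter), essentially none beyond the scatter, with a wide range to reflect the lack of any guiding comparison. Compound 3 is expected to give about 1500 nM, between 500 nM and 4500 nM.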

Compound 3, half-maximal inhibitory concentration: 2300 nM
Compound 3: middle estimate off by 1.5-fold (0.19 log units), on the low side; the range from low to high includes it.
By their numbers in this assay, from the lowest: compounds 2, 1 and 3 (each within the scatter of the next).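

Replacing chloro with the larger (isobutylcarbonyl)oxy on this aromatic carbon gives a 1.4-fold higher number from compound 1 to compound 3 (0.13 log units; within the scatter) in this assay, so the read-out does not separate the two groups. Within the data shown here, this is the first measured comparison at this place, and it shows that a carbonyl-bearing ester chain with hydrogen-bond acceptors, which chloro lacks, can stand here without a change beyond the scatter. No available measurement accounts for this result.

As far as these compounds go, whether the same holds for other groups on this carbon, such as an amine, a carboxylic acid or a longer ester chain, remains open. Compound 2 differs from compound 1 in more than one place, so it offers no clean comparison, and this single step cannot show how changes elsewhere on the shared core would behave.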